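Compound 2 to compound 3 in KYSE-70 cells

The source may report more compounds than this note shows. Statements on the series, on what has been measured and on what is new or still open speak of the compounds shown alone.

Measured so far:
compound 1 `O=C(Nc1cc(F)cc(F)c1)c1cc(=O)[nH]c2cc(F)ccc12`: > 20000 nM
compound 2 `O=C(Nc1cccc(F)c1)c1cc(=O)[nH]c2cc(-c3ccccc3F)ccc12`: > 20000 nM

Of the compounds shown here, two have been tested in a functional assay on KYSE-70 cells for antiproliferative activity against KYSE-70 cell line (Homo sapiens), read by MTT assay, with a stated time of 72 h; a higher number here means a weaker inhibitor, a lower number a stronger inhibitor. Compound 1 `O=C(Nc1cc(F)cc(F)c1)c1cc(=O)[nH]c2cc(F)ccc12` gives > 20000 nM, which is a limit of the assay rather than a number. Compound 2 `O=C(Nc1cccc(F)c1)c1cc(=O)[nH]c2cc(-c3ccccc3F)ccc12` gives > 20000 nM, again a limit. Compound 2 therefore stands at the edge of what this assay resolves, and no ranking against compound 1 is possible because of the limit of > 20000 nM in this assay, at which 2 of the 2 values shown sit.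

Compound 3 `O=C(Nc1cccc(F)c1)c1cc(=O)[nH]c2cc(-c3ccc(F)c(CO)c3)ccc12` has not yet been measured. It differs from compound 2 in one place: 4-fluoro-3-(hydroxymethyl)phenyl in place of 2-fluorophenyl on an aromatic carbon. Among the measured compounds shown here, no step between measured compounds is available, so the size of this change in this assay cannot be read from the present data; both measured values sit at the limit.

Compound 3 is expected at 18000 nM, within a range from 4000 nM to 60000 nM, and the assay is expected most often to report only a limit again. The step of an at least 1.1-fold lower number from compound 2 to compound 3 (0.04 log units; that floor lies within the scatter) that this estimate implies is expected to stay within the scatter.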

Compound 3, half-maximal inhibitory concentration: > 20000 nM
Compound 3 gave a limit, no number; the forecaster's own chance of this, stated with the estimate: 65%; middle value at least 1.1-fold (0.04 log units) away from the limit.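

No size can be read for the change from compound 2 to compound 3, because both values are limits and not numbers: the limit of > 20000 nM in this assay, at which 3 of the 3 values shown sit.

The compounds shown leave open whether 4-fluoro-3-(hydroxymethyl)phenyl in place of 2-fluorophenyl alters antiproliferative activity at all, and what actual number any compound of this series would give.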